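Ester to acid on a shared thiophene-free core of two compounds

The source may hold more compounds than are shown below. What is called first, only, known or untested is meant among the compounds shown, and "the series" means these compounds.

Compound 1 `COC(=O)c1c(Nc2ccc(OC)cc2)sc(C(=O)c2ccc(OC)cc2)c1C` and compound 2 `COC(=O)c1c(Nc2ccc(F)cc2)sc(C(=O)c2ccc(OC)cc2)c1C` differ only in one group on an aromatic carbon. In a functional assay, with a stated time of 150 min, tested at 30 ug/mL (a lower number here means a weaker effect, a higher number a stronger effect of the compound at the concentration tested), compound 1 gives 20.5%, and compound 2 gives 23.3%. The step of a number 2.8 percentage points higher from compound 1 to compound 2 (within the scatter) is a difference that repeated measurements of the same compound could also show, so the two numbers cannot be ranked; compound 2 simply holds the higher of the two readings.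

Compound 3 `COc1ccc(C(=O)c2sc(Nc3ccc(F)cc3)c(C(=O)O)c2C)cc1` is the next compound. It differs from compound 2 by hydrogen in place of methyl on an oxygen next to a carbonyl group. Among the compounds with values here, the only measured step, fluoro in place of methoxy on an aromatic carbon, changes a different part of the molecule and says nothing about swapping a methyl for a hydrogen on an oxygen next to a carbonyl group. Within the data shown here, no measured step therefore bears on this change, and there is no basis for expecting a shift in this assay in either direction beyond the scatter. The expected step of a number 1.3 percentage points lower from compound 2 to compound 3 (within the scatter) is set close to zero, with a wide range for the lack of guidance. The estimate for compound 3 in this assay is 22%, between 5% and 45%.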

Compound 3, a percentage reported as activity, at one concentration (the size of the read-out at that concentration, not a potency): 10.5%
Beside the measured number, compound 3's estimate is 11.5 percentage points above it, and the stated range covers the measured number.
By their numbers in this assay, from the lowest: compounds 3, 1 and 2 (each within the scatter of the next, the first and the last beyond it).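

Putting a hydrogen in place of the methyl on an oxygen next to a carbonyl group turns the methoxycarbonyl of compound 2 into the carboxy of compound 3, and in this assay this gives a number 12.8 percentage points lower from compound 2 to compound 3 (beyond the scatter). Within the data shown here, this is the first step here that lies beyond the scatter, whereas the change on the aromatic carbon, a number 2.8 percentage points higher from compound 1 to compound 2 (within the scatter), could not be told apart from repeat-to-repeat variation, so the methoxycarbonyl position is the first place in this small set where a single change clearly shifts the read-out at the tested concentration. Nothing measured here gives a reason for this drop.

Still open, on these data alone, is whether a longer chain on that oxygen, such as ethyl, or an amide in place of the methoxycarbonyl would stay close to compound 2 or fall toward compound 3. Also open, as far as these compounds go, is whether the same swap of methyl for hydrogen made on compound 1, which carries methoxy where compound 2 carries fluoro, would give a step of similar size and direction.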